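The source may hold more compounds than are shown below. What is called first, only, known or untested is meant among the compounds shown, and "the series" means these compounds.

Compound 1 `COc1ccc(-c2cc(/C=C/C(=O)c3ccc(N)cc3)[nH]n2)cc1` carries an amino-substituted aryl ketone on one end of the shared core and a 4-methoxyphenyl on the other. Among the measured compounds shown here, in a functional assay on U-251 cells (Homo sapiens) for cytotoxicity, read by sulforhodamine B assay, with a stated time of 48 h, tested at 10 uM (on this read-out lower numbers stand for a stronger effect and higher numbers for a weaker effect at the one concentration tested), compound 1 gives -94%, the second highest of the three numbers so far. Compound 3 `COc1ccc(C(=O)/C=C/c2cc(-c3cc(OC)c(OC)c(OC)c3)n[nH]2)cc1` gives -98%, within the scatter of compound 1. Compound 2 `COc1cc(-c2cc(/C=C/C(=O)c3ccc(Cl)c(Cl)c3)[nH]n2)cc(OC)c1OC` gives 48%, far above compound 1 and beyond the scatter. For the measured compounds named here, the one single-site step known, a number 146 percentage points lower from compound 2 to compound 3 (beyond the scatter), concerns the aryl on the carbonyl carbon and is large; nothing among the measured steps touches the aryl on the other side of the core.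

Compound 4 `COc1ccc(-c2cc(/C=C/C(=O)c3ccc(N)cc3)[nH]n2)cc1OC` differs from compound 1 by methoxy in place of hydrogen on an aromatic carbon, that is, a change on the pyrazole-side aryl. Going by the values given here, no measured step bears on this change directly. Among the compounds with values here, the only hint is that compound 1 and compound 3, which carry differently methoxylated aryls on that side but also differ elsewhere, show numbers within the scatter of each other. The expectation is therefore no step beyond the scatter in this assay, a number 2 percentage points higher from compound 1 to compound 4 (within the scatter). Compound 4 is estimated at -92%, with a range from -100% to -70%.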

Compound 4, a percentage reported as activity, at one concentration (the size of the read-out at that concentration, not a potency): -68%
Estimate against measurement, compound 4: 24 percentage points below, outside the stated range (above it).
By their numbers in this assay, from the lowest: compounds 3 and 1 (each within the scatter of the next); then compound 4; then compound 2.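

Methoxy in place of hydrogen on this aromatic carbon, ortho to a methoxy group and meta to a large group, gives the first single-site reading on this side of the shared core: in this assay there is a number 26 percentage points higher from compound 1 to compound 4 (beyond the scatter), so this position is not silent and the added methoxy weakens the effect. Among the compounds shown here, the step is modest, whereas the change of the aryl on the carbonyl carbon gives a number 146 percentage points lower from compound 2 to compound 3 (beyond the scatter), so the two sites of change are both open to variation but differ in the printed size of their steps, with only one step known at each. No measurement at hand accounts for the step from the hydrogen to the methoxy compound.

The compounds shown leave open whether the loss belongs to methoxy itself or to any substituent on this carbon, which a fluorine atom, a hydroxy group or a longer ethoxy chain there would separate. They also leave open whether the same step appears when the amino-substituted aryl on the carbonyl carbon is replaced by a 4-methoxyphenyl or a 3,4-dichlorophenyl.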